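Adding a trifluoromethyl group to a fragment-sized indazole inhibitor

A few compounds are considered here, and "the series" means these few. Any claim that something is new, unique, unknown or untested is made for them only; others in the source may bear on it.

Measured compounds:
compound 1, `O=[N+]([O-])c1ccccc1CNc1cccc2[nH]ncc12`: 25%
compound 2, `O=[N+]([O-])c1cc(Br)c(F)cc1CNc1cc(C(F)(F)F)cc2[nH]ncc12`: 31%
compound 3, `FC(F)(F)c1cc(NCc2cccc(Br)c2)c2cn[nH]c2c1`: 23%

The three compounds above were tested in an assay for inhibition of Indoleamine 2,3-dioxygenase 1 (Homo sapiens), with stated times of 10 min and 60 min, tested at 10 uM; a lower number here means a weaker effect, a higher number a stronger effect of the compound at the concentration tested. In this assay compound 1 gives 25%, compound 2 gives 31% and compound 3 gives 23%. Compound 1 stands with its number nearest to that of compound 3 and furthest from that of compound 2, yet both gaps fall within the usual scatter of repeated measurements, so the three numbers cannot be told apart with confidence.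

The step of interest leads from compound 1 to compound 4, `O=[N+]([O-])c1ccccc1CNc1cc(C(F)(F)F)cc2[nH]ncc12`, which has not yet been measured. The change is trifluoromethyl in place of hydrogen on an aromatic carbon. The same trifluoromethyl group is present in compound 2 and compound 3, and their numbers sit close to that of compound 1, which gives no sign that this group by itself moves the read-out far.

For compound 4 a step of a number 2 percentage points higher from compound 1 to compound 4 (within the scatter) is expected, that is, no change beyond the scatter in this assay. Compound 4 is therefore estimated at 27%, with a likely range from 14% to 40%.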

Compound 4, a percentage reported as inhibition, at one concentration (the size of the read-out at that concentration, not a potency): 35%
Estimate against measurement, compound 4: 8 percentage points below; low and high end bracket the measured number.
By their numbers in this assay, from the lowest: compounds 3, 1, 2 and 4 (each within the scatter of the next, the first and the last beyond it).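

Compound 1 and compound 4 differ in one place only, so this pair isolates trifluoromethyl in place of hydrogen, which compound 2 and compound 3 could not do because each differs from compound 1 in more than this one group. In this assay, the change on an aromatic carbon para to a fused ring gives a step of a number 10 percentage points higher from compound 1 to compound 4 (within the scatter), so the position accepts the group without any loss of the read-out, but this single pair does not establish a real gain. No measurement at hand offers an explanation for this result.

The compounds shown leave open whether a methyl group, a chlorine atom, a nitrile, an amine or a carboxylic acid at this same place would give a similar read-out, and so how much this position can accept beyond trifluoromethyl. They also leave open how the same change behaves with other groups elsewhere on the core, and what it does to potency, since a read-out at one concentration is not a potency.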